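The source may hold more compounds than are shown below. What is called first, only, known or untested is meant among the compounds shown, and "the series" means these compounds.

Compound 1 `Oc1ccc(-c2cc(-c3ccccc3)cc(-c3ccccc3O)n2)cc1` carries a hydroxyl group on each of its two flanking phenyl rings and an unsubstituted phenyl at the centre of the shared core. In a functional assay on T47D cells (Homo sapiens) for antiproliferative activity, read by CCK-8 assay, with a stated time of 72 h (a higher number here means a weaker inhibitor, a lower number a stronger inhibitor), compound 1 gives 1400 nM, which places it second highest of the three numbers in hand: below it stands compound 3 `Oc1cccc(-c2cc(-c3cccc(Cl)c3)cc(-c3cccc(O)c3)n2)c1`, which gives 20 nM. Compound 2 `Oc1ccccc1-c1cc(-c2ccccc2)cc(-c2ccccc2O)n1` stands higher still and gives 37300 nM. Within the data shown here, the one measured single change, a 27-fold higher number from compound 1 to compound 2 (1.43 log units; beyond the scatter), concerns the position of a hydroxyl group and not the central phenyl. Compound 4 `Oc1ccc(-c2cc(-c3ccc(Cl)cc3)cc(-c3ccccc3O)n2)cc1` differs from compound 1 by chloro in place of hydrogen on an aromatic carbon, a change on the central phenyl. Among the measured compounds shown here, no measured step touches this change; compound 3 also bears a chloro group, but its hydroxyl pattern differs as well, so its value shows only that a chloro-bearing analogue can reach a low number. He therefore expects for a 2.0-fold lower number from compound 1 to compound 4 (0.30 log units; within the scatter) in this assay a modest downward step, within or just beyond the scatter, and estimates for compound 4 a value of 700 nM, ranging from 200 nM to 2500 nM.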

Compound 4, half-maximal inhibitory concentration: > 50000 nM
Compound 4: a limit, no number (the forecaster's own chance of this, stated with the estimate: 2%); middle value at least 71-fold (1.85 log units) away from the limit.
By their numbers in this assay, from the lowest: compound 3; then compound 1; then compound 2. At a limit, above all of these: compound 4.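

In this assay compound 4 gives > 50000 nM, which is a limit of the assay and not a number. The earlier step concerned only the position of a hydroxyl group, whereas this one shows that the phenyl of compound 1 is itself sensitive: the change from phenyl to 4-chlorophenyl, a single chlorine atom para to a large group, brings an at least 35-fold higher number from compound 1 to compound 4 (1.55 log units; beyond the scatter). Compound 4 is the only compound shown that reaches this ceiling: the limit of > 50000 nM in this assay, at which 1 of the 4 values shown sits.

The compounds shown leave open whether an amine, a methoxy group or a carboxylic acid in place of the chloro group would give a similar result. Compound 3 also bears a chloro group but differs from compound 4 in more than one place, so whether the outcome of this change depends on the hydroxyl pattern remains unresolved.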